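Swapping the hydrazone aryl group in a sulfonamide triazine series

This account rests on a few compounds, and the source may have more. Where it says the series, first, only, none or still open, it means among the compounds named here.

Measured compounds:
compound 1, `NS(=O)(=O)c1ccc(Nc2nc(N/N=C/c3ccc(C(F)(F)F)cc3)nc(Nc3ccccc3)n2)cc1`, 3320 nM
compound 2, `Cc1nn(-c2ccccc2)cc1/C=N/Nc1nc(Nc2ccccc2)nc(Nc2ccc(S(N)(=O)=O)cc2)n1`, 3180 nM

Compound 1 is `NS(=O)(=O)c1ccc(Nc2nc(N/N=C/c3ccc(C(F)(F)F)cc3)nc(Nc3ccccc3)n2)cc1`. In a functional assay on OVCAR-3 cells (Homo sapiens) for inhibition, read by sulforhodamine B assay, with a stated time of 48 h (on this read-out higher numbers stand for weaker inhibition of growth and lower numbers for stronger inhibition of growth), compound 1 gives 3320 nM. Compound 2 is `Cc1nn(-c2ccccc2)cc1/C=N/Nc1nc(Nc2ccccc2)nc(Nc2ccc(S(N)(=O)=O)cc2)n1`; in this assay compound 2 gives 3180 nM. The two numbers sit close together: the step of a 1.0-fold lower number from compound 1 to compound 2 (0.02 log units; within the scatter) is within the scatter, so neither compound can be called the stronger of the pair.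

Compound 3 is `NS(=O)(=O)c1ccc(Nc2nc(N/N=C/c3ccccn3)nc(Nc3ccccc3)n2)cc1`. It differs from compound 2 by pyridin-2-yl in place of 3-methyl-1-phenyl-1H-pyrazol-4-yl on a carbon with a double bond to nitrogen. Going by the values given here, the only measured step that touches this position is a 1.0-fold lower number from compound 1 to compound 2 (0.02 log units; within the scatter), where a change of the same kind at the same place left the number essentially unchanged. On that single precedent, no step beyond the scatter is expected in this assay, in either direction.

Compound 3 is therefore expected to give about 3500 nM in this assay, with a range from 1200 nM to 10000 nM. This estimate means a step of a 1.1-fold higher number from compound 2 to compound 3 (0.04 log units; within the scatter), which is expected to stay within the scatter.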

Compound 3, concentration for 50% growth inhibition: 460 nM
Estimate against measurement, compound 3: 7.6-fold (0.88 log units) above; the measured number lies below the stated range.
By their numbers in this assay, from the lowest: compound 3; then compounds 2 and 1 (each within the scatter of the next).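

The position carrying the carbon with a double bond to nitrogen is not indifferent to its group, as the earlier pair alone had suggested with a 1.0-fold lower number from compound 1 to compound 2 (0.02 log units; within the scatter). In this assay, pyridin-2-yl gives a 6.9-fold lower number from compound 2 to compound 3 (0.84 log units; beyond the scatter) and a 7.2-fold lower number from compound 1 to compound 3 (0.86 log units; beyond the scatter), both beyond the scatter, so the number falls against either of the two earlier groups. No measurement in hand explains why compound 3 stands apart.

The change to compound 3 alters several things together: the ring nitrogen arrives as the second ring of the 3-methyl-1-phenyl-1H-pyrazol-4-yl group leaves, so the compounds shown cannot separate the effect of the pyridine nitrogen from that of having a single ring. A plain phenyl group at this place would be the direct comparison for compound 3.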